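Ring-closing the amide side chain of compound 3

A few compounds are considered here, and "the series" means these few. Any claim that something is new, unique, unknown or untested is made for them only; others in the source may bear on it.

Compounds measured so far, with their results in a functional assay on CHO cells for agonist activity at Free fatty acid receptor 1 (Homo sapiens); on this read-out higher numbers stand for an effect only at larger amounts of compound and lower numbers for an effect already at smaller amounts:
compound 1, `Cc1nc(-c2ccc(C(F)(F)F)cc2)sc1CNc1ccc(CCC(=O)O)cc1`: 67.6 nM
compound 2, `Cc1nc(-c2ccc(C(F)(F)F)cc2)sc1CNc1ccc(C(C)CC(=O)O)cc1`: 58.9 nM
compound 3, `Cc1nc(-c2ccc(C(F)(F)F)cc2)sc1CNc1ccc(CCC(N)=O)cc1`: 12.9 nM

Compound 3 stands at the lowest number of the three; the step of a 5.2-fold lower number from compound 1 to compound 3 (0.72 log units; beyond the scatter) and the step of a 4.6-fold lower number from compound 2 to compound 3 (0.66 log units; beyond the scatter) both lie beyond the scatter. Compound 4, `Cc1nc(-c2ccc(C(F)(F)F)cc2)sc1CNc1ccc([C@H]2C[C@@H]2C(N)=O)cc1`, carries the change (2-carbamoylcyclopropyl in place of 2-carbamoylethyl on an aromatic carbon). Going by the values given here, no measured step touches a three-membered ring. The nearest comparison is a 1.1-fold lower number from compound 1 to compound 2 (0.06 log units; within the scatter), where adding a methyl to the same side chain left the number unchanged within the scatter. On this thin basis the expected step of a 1.0-fold higher number from compound 3 to compound 4 (0.00 log units; within the scatter) is none beyond the scatter, with a wide range. Compound 4 is therefore estimated at 13 nM, between 4 nM and 45 nM.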

Compound 4, half-maximal effective concentration: 4.47 nM
Compound 4: middle estimate off by 2.9-fold (0.46 log units), on the high side; measured number inside the range.
By their numbers in this assay, from the lowest: compound 4; then compound 3; then compounds 2 and 1 (each within the scatter of the next).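

In this assay, tying the amide side chain into a three-membered ring gives a 2.9-fold lower number from compound 3 to compound 4 (0.46 log units; beyond the scatter), so at this position a 2-carbamoylcyclopropyl group lowers the number further, whereas the added methyl of compound 2 left it within the scatter. Against the acids, the change is larger, with a 13-fold lower number from compound 2 to compound 4 (1.12 log units; beyond the scatter) and a 15-fold lower number from compound 1 to compound 4 (1.18 log units; beyond the scatter), and these steps also replace the acid with the amide. No measurement at hand offers a reason for these steps.

Still open, on these data alone, is how the other stereoisomers of compound 4 would behave, and whether a cyclobutane ring or a nitrile in place of the amide would keep this low number.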